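The source may report more compounds than this note shows. Statements on the series, on what has been measured and on what is new or still open speak of the compounds shown alone.

Three compounds built on one shared core were tested in a functional assay on MDA-MB-231 cells (Homo sapiens) for antiproliferative activity, read by MTT assay, with a stated time of 72 h; a higher number here means a weaker inhibitor, a lower number a stronger inhibitor. Compound 1 `O=C(Nc1ccc(Cl)cc1)Nc1cccc(-c2nc(-c3ccc(NC(=O)c4cccnc4)cc3Cl)no2)c1` carries a chloro group on its outer aromatic ring; in this assay compound 1 gives > 10000 nM, which is a limit of the assay rather than a number (the limit of > 10000 nM in this assay, at which 1 of the 3 values shown sits). Compound 2 `COc1ccc(NC(=O)Nc2cccc(-c3nc(-c4ccc(NC(=O)c5cccnc5)cc4Cl)no3)c2)cc1` has methoxy in place of that chloro, and in this assay compound 2 gives 3000 nM. Compound 3 `CS(=O)(=O)Nc1ccc(NC(=O)Nc2cccc(-c3nc(-c4ccc(NC(=O)c5cccnc5)cc4Cl)no3)c2)cc1` has methanesulfonamido at the same place, and in this assay compound 3 gives 600 nM. The steps are an at least 3.3-fold lower number from compound 1 to compound 2 (0.52 log units; beyond the scatter), an at least 16-fold lower number from compound 1 to compound 3 (1.22 log units; beyond the scatter) and a 5.0-fold lower number from compound 2 to compound 3 (0.70 log units; beyond the scatter), so compound 3 stands lowest of the two numbers, with compound 2 nearest.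

Compound 4 `O=C(Nc1ccc(NS(=O)(=O)C2CC2)cc1)Nc1cccc(-c2nc(-c3ccc(NC(=O)c4cccnc4)cc3Cl)no2)c1` differs from compound 3 by cyclopropyl in place of methyl on a sulfonyl sulfur. Within the data shown here, none of the measured steps alters the group on the sulfonyl sulfur; they only show what arriving at the methanesulfonamido group did. Among the measured compounds shown here, no measured step therefore bears directly on this change, and the expected step is a 1.2-fold lower number from compound 3 to compound 4 (0.08 log units; within the scatter), which is none beyond the scatter. Compound 4 is estimated at 500 nM, with a likely range from 200 nM to 1500 nM.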

Compound 4, half-maximal inhibitory concentration: 300 nM
Beside the measured number, compound 4's estimate is 1.7-fold (0.22 log units) above it, within the range that was stated.
By their numbers in this assay, from the lowest: compounds 4 and 3 (each within the scatter of the next); then compound 2. At a limit, above all of these: compound 1.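

In this assay, this is the only step shown that alters the group on the sulfonyl sulfur, and it reads a 2.0-fold lower number from compound 3 to compound 4 (0.30 log units; within the scatter), so replacing methyl with cyclopropyl there gives two numbers that cannot be told apart. The sulfonamide-bearing compound 4 also stays well clear of the methoxy compound, with a 10-fold lower number from compound 2 to compound 4 (1.00 log units; beyond the scatter). The comparison with the chloro compound is only a bound, an at least 33-fold lower number from compound 1 to compound 4 (1.52 log units; beyond the scatter), since compound 1 stands at a limit and not at a number: the limit of > 10000 nM in this assay, at which 1 of the 4 values shown sits.

From the compounds shown here alone, with only methyl and cyclopropyl on the sulfur, it remains open how a longer chain such as n-butyl, a larger ring such as phenyl or an amine such as dimethylamino would behave there. Also open, going by these compounds, is what a methyl group on the sulfonamide nitrogen would do.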